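This account rests on a few compounds, and the source may have more. Where it says the series, first, only, none or still open, it means among the compounds named here.

Compound 1 `N#Cc1c(N)cccc1Sc1cccc(Cl)c1` gives 53000 nM in a functional assay on MT4 cells (Homo sapiens) for cytotoxicity; a higher number here means a weaker inhibitor, a lower number a stronger inhibitor. Compound 2 `Cc1cc(Cl)cc(Sc2cccc(N)c2C#N)c1` gives 16000 nM in this assay, and the step of a 3.3-fold lower number from compound 1 to compound 2 (0.52 log units; beyond the scatter) goes with methyl in place of hydrogen on an aromatic carbon. Compound 3 `Cc1cccc([S+]([O-])c2cccc(N)c2C#N)c1` carries a different core, and the difference between the two cores is not broken down here. In this assay compound 3 reaches only a limit, > 200000 nM, which is the limit of > 200000 nM in this assay, at which 1 of the 3 values shown sits. Compound 4 `Cc1cc(C)cc([S+]([O-])c2cccc(N)c2C#N)c1` is not yet measured and differs from compound 3 by methyl in place of hydrogen on an aromatic carbon. This is the same kind of change as that from compound 1 to compound 2, though the place here is meta to a large group and meta to a methyl group rather than meta to a chloro group and meta to a large group. On the pattern of a 3.3-fold lower number from compound 1 to compound 2 (0.52 log units; beyond the scatter), the step of an at least 1.3-fold lower number from compound 3 to compound 4 (0.12 log units; that floor lies within the scatter) is expected, while compound 3 itself stands only at a limit in this assay. Compound 4 is therefore expected to give about 150000 nM in this assay, most likely between 40000 nM and 400000 nM, and may itself come back only as a limit.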

Compound 4, half-maximal inhibitory concentration: 200000 nM
Compound 4: middle estimate off by 1.3-fold (0.12 log units), on the low side; low and high end bracket the measured number.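

In this assay, methyl in place of hydrogen on an aromatic carbon gives a number no higher from compound 3 to compound 4 (the limit leaves the size open), which sits without contradiction beside the earlier step but does not confirm that the change carries over in size. Compound 3 stands only at a limit, > 200000 nM, and not at a number. The two cores can therefore be set side by side only loosely: the same change on two cores in this assay, a 3.3-fold lower number (0.52 log units; beyond the scatter) from compound 1 to compound 2 and a number no higher (the limit leaves the size open) from compound 3 to compound 4; the limit leaves it open whether they differ

The compounds shown leave open how a methoxy group, an amine or a longer chain in place of that methyl would read in this assay. They also leave open what size the change has on the core of compound 3 when it starts from a number rather than a limit.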